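From Dimethylamino to Dichlorophenyl on the Shared Core

The source may report more compounds than this note shows. Statements on the series, on what has been measured and on what is new or still open speak of the compounds shown alone.

Measured compounds in a functional assay on ECa-109 cells (Homo sapiens) for cytotoxicity, read by MTT assay, with a stated time of 72 h; on this read-out lower numbers stand for stronger inhibition and higher numbers for weaker inhibition:
compound 1 `CN(C)c1ccc(C=C2C(=O)N(c3ccc(Cl)cc3)N(c3ccc(Cl)cc3)C2=O)cc1` gives > 128000 nM, which is a limit of the assay and not a number.
compound 2 `O=C1C(=Cc2ccc(F)cc2)C(=O)N(c2ccc(Cl)cc2)N1c1ccc(Cl)cc1` gives 35600 nM.
compound 3 `COc1cc(C=C2C(=O)N(c3ccc(Cl)cc3)N(c3ccc(Cl)cc3)C2=O)ccc1O` gives 7100 nM.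

Compound 1 stands only as a limit on these numbers: the limit of > 128000 nM in this assay, at which 1 of the 3 values shown sits, so its true place is not known. Compound 4 `O=C1C(=Cc2ccc(Cl)cc2Cl)C(=O)N(c2ccc(Cl)cc2)N1c1ccc(Cl)cc1` differs from compound 1 in one place: 2,4-dichlorophenyl in place of 4-(dimethylamino)phenyl on a double-bonded chain carbon bound to a double-bonded ring carbon. The step of an at least 3.5-fold lower number from compound 1 to compound 2 (0.55 log units; beyond the scatter), in which fluoro replaces dimethylamino on an aromatic carbon, bears most directly on this change; the step of an at least 18-fold lower number from compound 1 to compound 3 (1.25 log units; beyond the scatter) replaces the same 4-(dimethylamino)phenyl group and gave a larger shift. Compound 4 is therefore expected to give a lower number than the limit seen for compound 1, an expected step of an at least 5.8-fold lower number from compound 1 to compound 4 (0.76 log units; beyond the scatter) in this assay. Compound 4 is estimated at 22000 nM, within a range from 7000 nM to 70000 nM.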

Compound 4, half-maximal inhibitory concentration: 60200 nM
Compound 4: middle estimate off by 2.7-fold (0.44 log units), on the low side; the range from low to high includes it.
By their numbers in this assay, from the lowest: compound 3; then compounds 2 and 4 (each within the scatter of the next). At a limit, above all of these: compound 1.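

In this assay, 2,4-dichlorophenyl joins 4-fluorophenyl in giving a lower number than 4-(dimethylamino)phenyl at this place, with an at least 2.1-fold lower number from compound 1 to compound 4 (0.32 log units; beyond the scatter). Compound 1 is only a limit, so that step is a minimum: the limit of > 128000 nM in this assay, at which 1 of the 4 values shown sits. 2,4-Dichlorophenyl and 4-fluorophenyl cannot be told apart, with a 1.7-fold higher number from compound 2 to compound 4 (0.23 log units; within the scatter), whereas 4-hydroxy-3-methoxyphenyl stays clearly ahead, with an 8.5-fold higher number from compound 3 to compound 4 (0.93 log units; beyond the scatter).

On these data alone, it remains open whether 4-hydroxyphenyl or 3-methoxyphenyl alone would match the number of compound 3. Also open, as far as these compounds go, is how a carboxylic acid on the phenyl ring at this place would compare.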